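The source may report more compounds than this note shows. Statements on the series, on what has been measured and on what is new or still open speak of the compounds shown alone.

Compound 1, `CC(C)(C)Cc1c(-c2cccnc2)sc(N)c1C(=O)c1ccc(Cl)cc1`, in an assay on CHO cells for displacement of a labelled ligand from adenosine receptor A1 (Homo sapiens), read by scintillation counting, tested at 10 uM (a higher number here means more inhibition at the concentration tested (going by the name of the read-out), a lower number less inhibition), gives 1%.
Compound 2, `CC(C)(C)Cc1c(-c2cc(F)ccc2F)sc(N)c1C(=O)c1ccc(Cl)cc1`, in this assay gives 3%.
Compound 3, `CC(C)(C)Cc1c(-c2ccccc2)sc(N)c1C(=O)c1ccc(Cl)cc1`, in this assay gives 1%.

Compound 3 stands level with compound 1 at the digits shown, and together they are the lowest of the three numbers; the step between them reads no change at the digits printed from compound 1 to compound 3 (within the scatter), and the step from the furthest compound is a number 2 percentage points lower from compound 2 to compound 3 (within the scatter). All three numbers lie within the scatter of one another, so no ordering among them can be read.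

Compound 4, `COc1ccc(-c2sc(N)c(C(=O)c3ccc(Cl)cc3)c2CC(C)(C)C)cc1`, differs from compound 3 in one place: methoxy in place of hydrogen on an aromatic carbon. Among the measured compounds shown here, none of the measured steps changes this position; each swaps the whole aromatic group on the core, as in a number 2 percentage points higher from compound 1 to compound 2 (within the scatter), and every one of them stays within the scatter. Nothing in the measured set therefore points to a step beyond the scatter in this assay for this change, and compound 4 is expected to sit close to compound 3, a step of a number 2 percentage points higher from compound 3 to compound 4 (within the scatter). The estimate for compound 4 is 3%, ranging from 0% to 12%.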

Compound 4, a percentage reported as inhibition, at one concentration (the size of the read-out at that concentration, not a potency): 1%
Beside the measured number, compound 4's estimate is 2 percentage points above it; measured number inside the range.
By their numbers in this assay, from the lowest: compounds 1, 3, 4 and 2 (each within the scatter of the next).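

Among the compounds shown here, this is the first change made on the aromatic ring itself rather than a swap of the whole group: in this assay, methoxy on a carbon para to a large group gives no change at the digits printed from compound 3 to compound 4 (within the scatter) and so adds no step beyond the scatter. Set against the other aromatic groups, the 4-methoxyphenyl group gives a number 2 percentage points lower from compound 2 to compound 4 (within the scatter) and no change at the digits printed from compound 1 to compound 4 (within the scatter), so the new group joins the earlier ones with no order to be read among them. No further evidence bears on this result.

From the compounds shown here alone, because each number comes from one concentration and all lie within the scatter of one another, it remains open whether any group at this place can produce a clear step. An amine or a carboxylic acid at this carbon, or a longer chain in place of methoxy, could still behave differently.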